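The source may report more compounds than this note shows. Statements on the series, on what has been measured and on what is new or still open speak of the compounds shown alone.

Measured compounds:
Compound 1, `N#Cc1c(Nc2ccc(F)cc2)nc(SCc2cn(Cc3ccccc3Cl)nn2)nc1-c1ccccc1`, which in a functional assay on B16-F10 cells (Mus musculus) for inhibition, read by MTT assay, with a stated time of 72 h (on this read-out lower numbers stand for stronger inhibition and higher numbers for weaker inhibition), gives 5340 nM.
Compound 2, `Cc1ccc(Nc2nc(SCc3cn(Cc4ccccc4Cl)nn3)nc(-c3ccccc3)c2C#N)cc1`, which in this assay gives 3390 nM.

For the measured compounds named here, compound 2 has the lowest of the two numbers, but the only other compound, compound 1, lies within the scatter of it: a 1.6-fold lower number from compound 1 to compound 2 (0.20 log units; within the scatter). Nothing in these two values therefore orders compound 1 and compound 2 against each other.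

Compound 3, `COc1cc(-c2nc(SCc3cn(Cc4ccccc4Cl)nn3)nc(Nc3ccc(C)cc3)c2C#N)cc(OC)c1OC`, differs from compound 2 at one place: 3,4,5-trimethoxyphenyl in place of phenyl on an aromatic carbon. Going by the values given here, no measured step touches this place. Among the compounds with values here, the single step that has been measured, from compound 1 to compound 2, changes a substituent on the aryl amine and was itself within the scatter, so it says nothing about how the phenyl group next to the ring nitrogen responds to being replaced. The expectation for compound 3 in this assay can rest only on the size of the change and on the value of compound 2.

The expected step is a 1.4-fold lower number from compound 2 to compound 3 (0.13 log units; within the scatter), stated with a wide range. Compound 3 is estimated at 2500 nM, between 600 nM and 10000 nM.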

Compound 3, half-maximal inhibitory concentration: 20300 nM
Estimate against measurement, compound 3: 8.1-fold (0.91 log units) below; measured number above the stated range.
By their numbers in this assay, from the lowest: compounds 2 and 1 (each within the scatter of the next); then compound 3.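

In this assay, the position on the aromatic carbon next to the ring nitrogen and ortho to a cyano group now has its first reading: 3,4,5-trimethoxyphenyl in place of phenyl gives a 6.0-fold higher number from compound 2 to compound 3 (0.78 log units; beyond the scatter), which means weaker inhibition. For the compounds shown here, this is the only step among the three compounds that lies beyond the scatter, whereas the change of fluoro to methyl on the aromatic carbon, a 1.6-fold lower number from compound 1 to compound 2 (0.20 log units; within the scatter), separated nothing, so this phenyl position is the first place where a replacement shifts the read-out measurably. Nothing available bears on why the larger group with its three oxygen atoms goes with the higher number.

The compounds shown leave open whether the whole 3,4,5-trimethoxyphenyl group is needed for this shift or whether a phenyl carrying a single methoxy group would already produce it, and whether a smaller replacement such as a methyl group or a chlorine atom would move the number at all. They also leave open whether the same replacement would give a step of similar size on compound 1.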